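Side-chain changes in a three-compound cytotoxicity series

A few compounds are considered here, and "the series" means these few. Any claim that something is new, unique, unknown or untested is made for them only; others in the source may bear on it.

Of the compounds shown here, three have been measured so far. Compound 1 `CC(=O)OCCC(=O)O[C@H](CC=C(C)C)C1=CC(=O)c2c(O)ccc(O)c2C1=O` gives 17300 nM in a functional assay on HeLa cells (Homo sapiens) for cytotoxicity, read by MTT assay; on this read-out higher numbers stand for weaker inhibition and lower numbers for stronger inhibition. Compound 2 `CC(C)=CC[C@@H](OC(=O)c1ccco1)C1=CC(=O)c2c(O)ccc(O)c2C1=O` gives 80300 nM, and compound 3 `CCCC(CC(=O)O[C@H](CC=C(C)C)C1=CC(=O)c2c(O)ccc(O)c2C1=O)OC(C)=O` gives 51200 nM. Compound 3 holds the second highest of the three numbers: its nearest neighbour is compound 2, with a 1.6-fold lower number from compound 2 to compound 3 (0.20 log units; within the scatter), and its furthest is compound 1, with a 3.0-fold higher number from compound 1 to compound 3 (0.47 log units; beyond the scatter).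

Compound 4 `CCCCCCC(C)(O)CC(=O)O[C@H](CC=C(C)C)C1=CC(=O)c2c(O)ccc(O)c2C1=O` has not yet been measured. The change from compound 3 to compound 4 is 1-hydroxy-1-methylheptyl in place of 1-acetoxybutyl on a saturated chain carbon bound to a carbonyl carbon.

Going by the values given here, two measured steps bear on this. The step from compound 1 to compound 3, a 3.0-fold higher number from compound 1 to compound 3 (0.47 log units; beyond the scatter), shows a modest weakening when the chain on the ester side is extended by a propyl group. The step from compound 1 to compound 2, a 4.6-fold higher number from compound 1 to compound 2 (0.67 log units; beyond the scatter), shows that a wholly different acyl group also weakens inhibition modestly. Neither step places a 1-hydroxy-1-methylheptyl group on a saturated chain carbon bound to a carbonyl carbon, so the precedent is indirect. The expectation is a step within the scatter, with a slight lean toward a higher number.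

Compound 4 is expected to give 60000 nM, with a range from 20000 nM to 180000 nM. This corresponds to an expected step of a 1.2-fold higher number from compound 3 to compound 4 (0.07 log units; within the scatter).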

Compound 4, half-maximal inhibitory concentration: > 100000 nM
Compound 4 gave a limit, no number; the forecaster's own chance of this, stated with the estimate: 10%; middle value at least 1.6-fold (0.22 log units) from the limit.
By their numbers in this assay, from the lowest: compound 1; then compounds 3 and 2 (each within the scatter of the next). At a limit, above all of these: compound 4.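

In this assay compound 4 gives a limit of the assay and not a number: the limit of > 100000 nM in this assay, at which 1 of the 4 values shown sits. Going by these compounds alone, on a saturated chain carbon bound to a carbonyl carbon, the 1-hydroxy-1-methylheptyl group gives an at least 5.7-fold higher number from compound 1 to compound 4 (0.76 log units; beyond the scatter), so this hydroxy-bearing chain does not bring inhibition back to the level of compound 1, and the floor of this step is the only one of the new steps that is beyond the scatter. The other two steps are an at least 1.9-fold higher number from compound 3 to compound 4 (0.29 log units; that floor lies within the scatter) and an at least 1.2-fold higher number from compound 2 to compound 4 (0.09 log units; that floor lies within the scatter), and as both floors lie within the scatter, the limit fixes no order among the three compounds involved.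

The change from 1-acetoxybutyl to 1-hydroxy-1-methylheptyl alters the chain and the oxygen substituent together, and the compounds shown leave open which of the two carries the step. A 1-hydroxybutyl group or a 1-aminobutyl group in the same place would test the substituent on the shorter chain, and a true number for compound 4 would be needed to give the size of its steps.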